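Swapping chloro for methoxy on the pendant phenyl ring

This account rests on a few compounds, and the source may have more. Where it says the series, first, only, none or still open, it means among the compounds named here.

Of the compounds shown here, three that share one core have been tested in a functional assay on MCF7 cells (Homo sapiens) for cytotoxicity, read by MTT assay, with a stated time of 96 h; a lower number here means a stronger inhibitor, a higher number a weaker inhibitor. Compound 1 `COc1cc(C(=O)c2cn(-c3cccc(Cl)c3)cc2-c2ccccc2)cc(OC)c1OC` gives 150 nM. Compound 3 `COc1cc(C(=O)c2cn(-c3ccccc3)cc2-c2ccc(Cl)cc2)cc(OC)c1OC` gives 290 nM, the highest of the two plain numbers, though its gap to compound 1 lies within the scatter. For compound 2 `COc1cc(C(=O)c2cn(-c3cc(OC)c(OC)c(OC)c3)cc2-c2ccccc2)cc(OC)c1OC` the assay reports only a limit, > 5000 nM. For the measured compounds named here, the one measured step, an at least 33-fold higher number from compound 1 to compound 2 (1.52 log units; beyond the scatter), concerns a different ring from the one altered here, so it bears only loosely on the present change.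

Compound 4 `COc1ccc(-c2cn(-c3ccccc3)cc2C(=O)c2cc(OC)c(OC)c(OC)c2)cc1` differs from compound 3 by methoxy in place of chloro on an aromatic carbon. Going by the values given here, with no measured step on this ring, a modest shift at most is expected, a 1.4-fold higher number from compound 3 to compound 4 (0.14 log units; within the scatter). Compound 4 is therefore estimated at 400 nM, between 150 nM and 1200 nM.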

Compound 4, half-maximal inhibitory concentration: 70 nM
Compound 4: middle estimate off by 5.7-fold (0.76 log units), on the high side; measured number below the stated range.
By their numbers in this assay, from the lowest: compound 4; then compounds 1 and 3 (each within the scatter of the next). At a limit, above all of these: compound 2.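

In this assay, going from 4-chlorophenyl to 4-methoxyphenyl gives a 4.1-fold lower number from compound 3 to compound 4 (0.62 log units; beyond the scatter) and so shows that the number responds to the group at this place on the ring, with methoxy giving the stronger result of the two. For the compounds shown here, this is the first measured step on this ring, and it is beyond the usual scatter. Nothing shown here explains why the number falls.

On these data alone, whether a dimethylamino group, a carboxylic acid or a longer chain such as butoxy would fall further or rise remains open. So does whether methoxy would give a similar step elsewhere on this ring.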